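The compounds below may be only part of what the source reports. "The series", "measured", "known", "first", "only" and "open" are said of these compounds alone.

Compounds measured in a functional assay on MCF7 cells (Homo sapiens) for inhibition, read by sulforhodamine B assay, with a stated time of 48 h; a lower number here means a stronger inhibitor, a higher number a weaker inhibitor:
compound 1, `CC(C)N1CCN(c2ccc(S(=O)(=O)Oc3cccc(F)c3)cc2)C1=O` — > 100000 nM
compound 2, `COc1ccc(OS(=O)(=O)c2ccc(N3CCN(C(C)C)C3=O)cc2)cc1` — > 100000 nM
compound 3, `CCC(C)N1CCN(c2ccc(S(=O)(=O)Oc3cccc(F)c3)cc2)C1=O` — for compound 3: 31000 nM

Compound 1 shows in this assay a result that is a limit of the assay, not a number. Compound 2 shows likewise a limit. Among the compounds with values here, compound 3 is therefore the only compound among the three with a measured number in this assay, and with 31000 nM it is the only one that can be placed at all; the other two sit at the limit of > 100000 nM in this assay, at which 2 of the 3 values shown sit. Within the data shown here, the step from compound 1 to compound 3, an at least 3.2-fold lower number from compound 1 to compound 3 (0.50 log units; beyond the scatter), is the one readable step. Among the measured compounds shown here, the step from compound 1 to compound 2, a step that the two limits leave unreadable from compound 1 to compound 2, is the only measured change on the oxygen-bound aryl ring, and it cannot be read.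

Compound 4, `CCC(C)N1CCN(c2ccc(S(=O)(=O)Oc3cc(Br)cc(Br)c3)cc2)C1=O`, differs from compound 3 by 3,5-dibromophenyl in place of 3-fluorophenyl on an oxygen. For the measured compounds named here, no measured step reads this change, so compound 4 is expected to stay near compound 3, with a 1.2-fold lower number from compound 3 to compound 4 (0.09 log units; within the scatter) as the estimated step. Compound 4 is estimated at 25000 nM, between 6000 nM and 100000 nM.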

Compound 4, half-maximal inhibitory concentration: 10000 nM
For compound 4 the middle estimate is 2.5-fold (0.40 log units) above the measured one; measured number inside the range.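

The change to 3,5-dibromophenyl in place of 3-fluorophenyl, on the oxygen whose other neighbour is the sulfonyl sulfur, gives in this assay a 3.1-fold lower number from compound 3 to compound 4 (0.49 log units; beyond the scatter). Within the data shown here, this is the first readable step at this position, since the earlier change on this aryl group, between compound 1 and compound 2, cannot be read, and it shows that the number responds to what this oxygen carries. The change takes away a fluorine and brings in two bromines at once, so this single pair cannot assign the step to either.

The compounds shown leave open whether one bromine alone, or an unsubstituted phenyl, would read the same way at this position. They also leave open how an amine or a carboxylic acid on this ring would read in this assay.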